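This account rests on a few compounds, and the source may have more. Where it says the series, first, only, none or still open, it means among the compounds named here.

Measured in a functional assay on K562 cells (Homo sapiens) for antiproliferative activity; a lower number here means a stronger inhibitor of growth, a higher number a weaker inhibitor of growth:

- compound 1 `CCCCCOCCCCCCC/C=C1\CC(CO)(COC(=O)C(C)(C)C)OC1=O`: 1.15 ug/mL
- compound 2 `CC(C)(C)C(=O)OCC1(CO)C/C(=C/CCCCCCCCCCCCCCC=O)C(=O)O1`: 2.58 ug/mL

Of these two compounds, compound 1 has the lower number, at 1.15 ug/mL, so it is the stronger inhibitor of growth. Compound 2 stands higher by more than the usual scatter of repeated measurements.

The next compound to consider is compound 3 `CC(=O)NCCCCCCCCCCCCCCC/C=C1\CC(CO)(COC(=O)C(C)(C)C)OC1=O`, which differs from compound 1 in one place: 8-acetamidooctyl in place of pentyloxy on a saturated chain carbon, seven bonds along the chain from a double-bonded chain carbon. In words, this is 8-acetamidooctyl in place of pentyloxy on a saturated chain carbon, seven bonds along the chain from a double-bonded chain carbon.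

Among the measured compounds shown here, no measured pair isolates this change, so the evidence is thin. For the measured compounds named here, the only guide is compound 2, whose long side chain also lacks the pentyloxy group and which gives 2.58 ug/mL. On that basis, a modest loss of growth inhibition in this assay is expected, perhaps only slightly beyond the scatter. The expected change is a 2.0-fold higher number from compound 1 to compound 3 (0.30 log units; within the scatter). For compound 3 the estimated value is 2.3 ug/mL, with an expected range from 0.9 ug/mL to 6 ug/mL.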

Compound 3, concentration for 50% growth inhibition: 3.38 ug/mL
Estimate against measurement, compound 3: 1.5-fold (0.17 log units) below, within the range that was stated.
By their numbers in this assay, from the lowest: compound 1; then compounds 2 and 3 (each within the scatter of the next).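

In this assay, 8-acetamidooctyl in place of pentyloxy on a saturated chain carbon, seven bonds along the chain from a double-bonded chain carbon, gives a 2.9-fold higher number from compound 1 to compound 3 (0.47 log units; beyond the scatter). Among the compounds shown here, this is the first direct reading at this position: the change costs some growth inhibition, but the loss is modest, and compound 3 still gives 3.38 ug/mL. The swap brings in a larger group and adds a hydrogen-bond donor in a single step, so this one comparison cannot separate those two differences, and no measurement at hand explains the loss.

The compounds shown leave open whether the weaker inhibition follows the larger group or the amide itself, a question that a plain octyl group at the same place could help to settle. They also leave open how a chain ending in an amine or a carboxylic acid, or a shorter chain carrying the same acetamido end, would read in this assay.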